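The compounds below may be only part of what the source reports. "The series", "measured", "known", "first", "only" and "open" are said of these compounds alone.

Of the compounds shown here, three sharing one core have been measured in a functional assay on HeLa cells (Homo sapiens) for inhibition, read by CCK-8 assay, with a stated time of 48 h; on this read-out higher numbers stand for weaker inhibition and lower numbers for stronger inhibition. There, compound 1 `COc1cc(-c2ccnc3cc(-c4ccc(F)cc4)nn23)cc(OC)c1OC` gives 5840 nM against a much lower reading for compound 2 `COc1cc(-c2ccnc3cc(-c4ccc5cc[nH]c5c4)nn23)cc(OC)c1OC` at 125 nM in the same test. Compound 3 `COc1cc(-c2ccnc3cc(-c4cn(C)c5ccccc45)nn23)cc(OC)c1OC` gives 399 nM and so holds the middle of the three numbers, above compound 2 and below compound 1.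

Compound 4 `COc1cc(-c2ccnc3cc(-c4ccc(C(C)=O)cc4)nn23)cc(OC)c1OC` carries 4-acetylphenyl in place of 1-methyl-1H-indol-3-yl on an aromatic carbon of the five-membered aromatic ring (4-acetylphenyl in place of 1-methyl-1H-indol-3-yl on an aromatic carbon). The closest evidence is the change that brought in 1-methyl-1H-indol-3-yl for 4-fluorophenyl, which gave a 15-fold lower number from compound 1 to compound 3 (1.17 log units; beyond the scatter) at the same place. The change to 1H-indol-6-yl gave a 47-fold lower number from compound 1 to compound 2 (1.67 log units; beyond the scatter) and points the same way, while the exchange between the two indole groups gave only a 3.2-fold higher number from compound 2 to compound 3 (0.50 log units; beyond the scatter) as a modest step.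

Read in reverse, these steps lead one to expect a large rise in the number in this assay on leaving the indole group for a phenyl group. Going by the values given here, no compound with an acetyl group has been measured, so a full return to the level of compound 1 is not assured. The expected step is a 7.5-fold higher number from compound 3 to compound 4 (0.88 log units; beyond the scatter) on this estimate. Compound 4 is estimated at 3000 nM (range 900 nM to 10000 nM).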

Compound 4, half-maximal inhibitory concentration: 1810 nM
Beside the measured number, compound 4's estimate is 1.7-fold (0.22 log units) above it; measured number inside the range.
By their numbers in this assay, from the lowest: compound 2; then compound 3; then compound 4; then compound 1.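

In this assay, a phenyl group at this aromatic carbon of the five-membered ring is not tied to the high end of the series: acetyl in place of fluoro on that phenyl gives a 3.2-fold lower number from compound 1 to compound 4 (0.51 log units; beyond the scatter), so the group carried by the phenyl ring itself moves the number. That shift does not close the gap to the indole groups, since replacing them with 4-acetylphenyl gives a 4.5-fold higher number from compound 3 to compound 4 (0.66 log units; beyond the scatter) for the 1-methyl-1H-indol-3-yl group and a 14-fold higher number from compound 2 to compound 4 (1.16 log units; beyond the scatter) for the 1H-indol-6-yl group, which places the 4-acetylphenyl group between the indole groups and 4-fluorophenyl in this series. No evidence on the cause of these differences is available.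

The compounds shown leave open whether a 4-methoxyphenyl, 4-aminophenyl or 4-carboxyphenyl group would give a number nearer the indole compounds or nearer compound 1. Going by these compounds, it also remains open whether a methyl group on the nitrogen of the 1H-indol-6-yl group would shift the number of compound 2, as the two indole groups here differ both in that methyl group and in their point of attachment.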